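Piperidin-1-yl amide of compound 3: expected cytotoxicity

This account rests on a few compounds, and the source may have more. Where it says the series, first, only, none or still open, it means among the compounds named here.

Measured compounds:
compound 1 `O=C1C=CC(=O)C(c2cc(-c3ccc(C(=O)N4CCCCC4)s3)on2)=C1` gives > 30000 nM
compound 2 `CN(Cc1ccc(F)cc1)C(=O)c1ccc(-c2cc(C3=CC(=O)C=CC3=O)no2)s1` gives > 30000 nM
compound 3 `COc1ccc(OC)c(-c2cc(-c3ccc(C(=O)N(C)Cc4ccc(F)cc4)s3)on2)c1` gives > 30000 nM

All three values come from a functional assay on PC-3 cells (Homo sapiens) for cytotoxicity, read by XTT assay, with a stated time of 72 h; on this read-out higher numbers stand for weaker inhibition and lower numbers for stronger inhibition. In this assay compound 1 reaches only a limit, > 30000 nM, not a number. Compound 2 likewise gives only a limit, > 30000 nM. Compound 3 also gives only a limit, > 30000 nM. These three limits together form (the limit of > 30000 nM in this assay, at which 3 of the 3 values shown sit).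

Compounds 2 and 1 share a core and differ in one place: piperidin-1-yl in place of (4-fluorobenzyl)(methyl)amino on a carbonyl carbon. The step that the two limits leave unreadable from compound 2 to compound 1 cannot be read, because both ends sit at the limit (the limit of > 30000 nM in this assay, at which 3 of the 3 values shown sit). Compound 2 and compound 3 differ in their cores: a group of 10 heavy atoms (8 carbon, 2 oxygen; one six-membered aromatic ring of carbon only) in place of a group of 8 heavy atoms (6 carbon, 2 oxygen; one six-membered non-aromatic ring of carbon only), on an aromatic carbon. The step that the two limits leave unreadable from compound 2 to compound 3 is likewise unreadable for the same reason, (the limit of > 30000 nM in this assay, at which 3 of the 3 values shown sit).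

Compound 4 `COc1ccc(OC)c(-c2cc(-c3ccc(C(=O)N4CCCCC4)s3)on2)c1` is not yet measured. It differs from compound 3 in one place: piperidin-1-yl in place of (4-fluorobenzyl)(methyl)amino on a carbonyl carbon. This is the same change that leads from compound 2 to compound 1, made at a place described in the same words, so it is the same change on the other core.

Because the limit of > 30000 nM in this assay, at which 3 of the 3 values shown sit, shows every measured compound, including compound 3 with > 30000 nM, at the limit, compound 4 is expected to stay there too, and the expected step that the limit leaves unreadable from compound 3 to compound 4 is taken as small. The estimate for compound 4 is 60000 nM, expected to lie between 20000 nM and 300000 nM, most likely reported again only as a limit.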

Compound 4, half-maximal inhibitory concentration: > 30000 nM
Compound 4 gave a limit, no number; the forecaster's own chance of this, stated with the estimate: 90%; the middle value lies beyond the limit too.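

No step can be read from compound 3 to compound 4, because both compounds give only a limit and not a number: the limit of > 30000 nM in this assay, at which 4 of the 4 values shown sit.

The compounds shown leave open whether putting piperidin-1-yl in place of (4-fluorobenzyl)(methyl)amino on the carbonyl carbon changes cytotoxicity at all, and which structure would give a measured number instead of a limit.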